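The source may hold more compounds than are shown below. What is called first, only, known or untested is meant among the compounds shown, and "the series" means these compounds.

Working notes on the series, measured in an ADME assay on MDBK cells (Bos taurus) for cytotoxicity, read by MTT assay, with a stated time of 96 h; on this read-out higher numbers stand for lower toxicity in this test and lower numbers for higher toxicity in this test.

Compound 1 `CN1CCN(CC(=O)Nc2ccc(-c3nc4cc(C(F)(F)F)ccc4n3C)cc2)CC1` gives 44000 nM in this assay. Compound 3 `O=C(CN1CCCCC1)Nc1ccc(-c2nc3cc(Cl)c(Cl)cc3[nH]2)cc1` gives 45000 nM in this assay, and the two values sit within the usual scatter of each other, so no order between compound 1 and compound 3 can be read from them. Within the data shown here, compound 2 `CCC(=O)Nc1ccc(-c2nc3cc(C(F)(F)F)ccc3[nH]2)cc1` gives only a limit in this assay, > 100000 nM, and not a number; it is the one value here that sits at that limit (the limit of > 100000 nM in this assay, at which 1 of the 3 values shown sits).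

Compound 4 `Cn1c(-c2ccc(NC(=O)CN3CCN(c4ccccc4)CC3)cc2)nc2cc(C(F)(F)F)ccc21` has not yet been measured in this assay. It differs from compound 1 at one place: phenyl in place of methyl on an amine nitrogen in a ring. Among the measured compounds shown here, no measured pair shows this change, so the size of the step has to be guessed. A step toward a lower number, beyond the scatter, is expected from compound 1 to compound 4, a 2.2-fold lower number from compound 1 to compound 4 (0.34 log units; beyond the scatter), though a step within the scatter cannot be excluded. For compound 4 a value of 20000 nM is estimated in this assay, in the range 6000 nM to 70000 nM.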

Compound 4, half-maximal cytotoxic concentration: 1400 nM
Compound 4: the middle estimate sits 14-fold (1.15 log units) above what was measured, outside the stated range (below it).
By their numbers in this assay, from the lowest: compound 4; then compounds 1 and 3 (each within the scatter of the next). At a limit, above all of these: compound 2.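

Among these compounds, the change from 4-methylpiperazin-1-yl to 4-phenylpiperazin-1-yl gives the first step that can be read in this assay: a 31-fold lower number from compound 1 to compound 4 (1.50 log units; beyond the scatter). This shows that the amine nitrogen in the ring is not a silent position on this read-out, as one change there moves the number toward higher toxicity in this test by a large step. Nothing measured among these compounds accounts for the size of this step.

From the compounds shown here alone, it remains open whether the step belongs to the aromatic ring as such or to the added carbon atoms, a question on which a cyclohexyl or benzyl group at this nitrogen would bear. Among the compounds shown here, also open is whether the same change gives a step of similar size on another core; only one pair shows it so far.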